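This account rests on a few compounds, and the source may have more. Where it says the series, first, only, none or still open, it means among the compounds named here.

In a functional assay on MCF7 cells (Homo sapiens) for inhibition, read by MTT assay, with a stated time of 48 h (on this read-out lower numbers stand for stronger inhibition and higher numbers for weaker inhibition), compound 1 `c1ccc(C(c2c[nH]c3ccccc23)c2c[nH]c3ccccc23)cc1` gives 22200 nM, while compound 2 `COc1ccc(C(c2c[nH]c3ccc(Br)cc23)c2c[nH]c3ccc(Br)cc23)cc1` gives 2300 nM. Compound 2 therefore has the lower of the two numbers, and the gap between them lies beyond the usual scatter of repeated measurements. These two compounds differ in more than one place, so their gap cannot be tied to any single change. Compound 3 `CN(C)c1ccc(C(c2c[nH]c3ccc(Br)cc23)c2c[nH]c3ccc(Br)cc23)cc1` differs from compound 2 in one place: dimethylamino in place of methoxy on an aromatic carbon, with dimethylamino in place of methoxy on an aromatic carbon. Among the measured compounds shown here, no pair of measured compounds shows what this swap does, so the expectation stays close to compound 2 at 2300 nM. The estimated step of a 1.2-fold lower number from compound 2 to compound 3 (0.06 log units; within the scatter) in this assay is expected to stay within the scatter, with neither direction favoured. Compound 3 is estimated at 2000 nM, with an expected range of 700 nM to 6000 nM.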

Compound 3, half-maximal inhibitory concentration: 24900 nM
The estimate for compound 3 lay 12-fold (1.10 log units) below the measured number, and the stated range ends below it.
By their numbers in this assay, from the lowest: compound 2; then compounds 1 and 3 (each within the scatter of the next).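

Among the compounds shown here, this is the first single change that can be read in this assay: dimethylamino in place of methoxy, on an aromatic carbon para to a large group, gives an 11-fold higher number from compound 2 to compound 3 (1.03 log units; beyond the scatter). The position is therefore sensitive to what sits on it, even though these two groups have the same counts of hydrogen-bond donors and acceptors. Nothing measured here explains the size of this step.

Going by these compounds, the change is seen only once, on the core of compound 2, so whether it would carry over to the core of compound 1 remains open. It is also unclear whether methoxy is unusually favourable or dimethylamino unusually unfavourable, a question that a hydroxyl group, a fluorine atom or a primary amine at this position could help to settle.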